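A few compounds are considered here, and "the series" means these few. Any claim that something is new, unique, unknown or untested is made for them only; others in the source may bear on it.

Compound 3 `COc1ccc(S(=O)(=O)NCCN2CCC(CCC(=O)c3cc(Cl)c(N)cc3OC)CC2)cc1` stands highest of the two numbers in an assay on HEK293 cells for displacement of a labelled ligand from 5-hydroxytryptamine receptor 6 (Homo sapiens), with a stated time of 60 min, tested at 0.01 uM, in the presence of a further agent that is not named here (on this read-out lower numbers stand for a weaker effect and higher numbers for a stronger effect at the one concentration tested), where compound 3 gives 36%. Compound 1 `COc1ccc(S(=O)(=O)NCCN2CCC(CCC(=O)c3cc(Cl)c(N)cc3OC)CC2)cc1Cl` gives 20%, and the step of a number 16 percentage points higher from compound 1 to compound 3 (beyond the scatter) separates them, with hydrogen in place of chloro on an aromatic carbon. Compound 2 `COc1ccc(S(=O)(=O)NCCN2CCC(CCC(=O)c3cc(Cl)c(N)cc3OC)CC2)cc1Br` is reported in this assay as "not active" (no number reported), with no number given. Compound 4 `COc1cc(N)c(Cl)cc1C(=O)CCC1CCN(CCNS(=O)(=O)c2ccc(C)cc2)CC1` differs from compound 3 by methyl in place of methoxy on an aromatic carbon. For the measured compounds named here, none of the measured steps concerns this exchange of methyl for methoxy: the one step known swaps chloro for hydrogen on an aromatic carbon, so neither size nor direction can be read from it. The step of a number 4 percentage points lower from compound 3 to compound 4 (within the scatter) is therefore expected to stay within the scatter. Compound 4 is estimated to give about 32% in this assay, between 12% and 52%.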

Compound 4, a percentage reported as inhibition, at one concentration (the size of the read-out at that concentration, not a potency): "not active" (no number reported)
Compound 4: no number reported, so the estimate cannot be set against anything.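

For the compounds shown here, compound 4 has no number, and no step from compound 3 to compound 4 can be read. As far as these compounds go, how methyl in place of methoxy shifts this read-out stays open. No supporting evidence bears on this result.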